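The source may report more compounds than this note shows. Statements on the series, on what has been measured and on what is new or still open speak of the compounds shown alone.

Of the compounds shown here, three sharing one core have been tested in a functional assay on MCF7 cells (Homo sapiens) for cytotoxicity, read by neutral red uptake, with a stated time of 3 days; on this read-out higher numbers stand for weaker inhibition and lower numbers for stronger inhibition. Compound 1 `CCc1c(F)c(N)c2c(=O)cc(-c3ccc(N)c(F)c3)oc2c1F` gives 130 nM in this assay. Compound 2 `CCCCc1c(F)c(N)c2c(=O)cc(-c3ccc(N)c(F)c3)oc2c1F` gives 8800 nM. Compound 3 `Nc1ccc(-c2cc(=O)c3c(N)c(F)c(CO)c(F)c3o2)cc1F` gives 62 nM, the lowest of the three numbers and thus the strongest inhibitor here, since both of its steps to the others lie beyond the scatter: a 2.1-fold lower number from compound 1 to compound 3 (0.32 log units; beyond the scatter) and a 140-fold lower number from compound 2 to compound 3 (2.15 log units; beyond the scatter). The third step, a 68-fold higher number from compound 1 to compound 2 (1.83 log units; beyond the scatter), shows how strongly this assay answers to a change at the same spot.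

Compound 4 `Nc1ccc(-c2cc(=O)c3c(N)c(F)c(C(=O)O)c(F)c3o2)cc1F` is not yet measured. It differs from compound 3 by carboxy in place of hydroxymethyl on an aromatic carbon. Within the data shown here, no measured step shows a carboxy group, so the step of a 2.1-fold lower number from compound 1 to compound 3 (0.32 log units; beyond the scatter) is the closest guide; it was modest, while the chain growth in a 68-fold higher number from compound 1 to compound 2 (1.83 log units; beyond the scatter) was large. Because a 2.1-fold lower number from compound 1 to compound 3 (0.32 log units; beyond the scatter) was small, the step of a 2.4-fold higher number from compound 3 to compound 4 (0.38 log units; beyond the scatter) is expected to be modest, its direction uncertain, with some risk of a weaker result. Compound 4 is therefore estimated at 150 nM, with a likely range from 40 nM to 600 nM.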

Compound 4, half-maximal inhibitory concentration: > 10000 nM
Compound 4: no number, only a limit; the forecaster's own chance of this, stated with the estimate: 5%; at least 66-fold (1.82 log units) between middle value and limit.
By their numbers in this assay, from the lowest: compound 3; then compound 1; then compound 2. At a limit, above all of these: compound 4.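

Compound 4 gives no number, only a limit of the read-out: the limit of > 10000 nM in this assay, at which 1 of the 4 values shown sits. Until now only lengthening the chain to butyl had cost much at this aromatic carbon, yet carboxy in place of hydroxymethyl, with the counts of hydrogen-bond donors and acceptors unchanged, also costs a great deal, as an at least 160-fold higher number from compound 3 to compound 4 (2.20 log units; beyond the scatter) and an at least 76-fold higher number from compound 1 to compound 4 (1.88 log units; beyond the scatter) show, so a short group here does not guarantee that activity is kept. The third step, an at least 1.1-fold higher number from compound 2 to compound 4 (0.05 log units; that floor lies within the scatter), is too small a floor to rank that pair.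

The compounds shown leave open how a methyl ester, a primary amide or an aminomethyl group would read at this carbon. Those groups could show whether the loss belongs to the carboxylic acid itself or extends to other carbonyl groups.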